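Moving the amide in a piperidine-bearing agonist series

This account rests on a few compounds, and the source may have more. Where it says the series, first, only, none or still open, it means among the compounds named here.

Compound 1 `NC(=O)CC1CCN(c2nc(-c3cc(F)c(Cl)cc3F)nc3c2CS(=O)(=O)C3)CC1`: 8.3 nM
Compound 2 `NC(=O)C1CCN(c2nc(-c3cc(F)c(Cl)cc3F)nc3c2CS(=O)(=O)C3)CC1`: 21 nM
Compound 3 `NC(=O)CCC1CCN(c2nc(-c3cc(F)c(Cl)cc3F)nc3c2CS(=O)(=O)C3)CC1`: 18 nM

In a functional assay on HEK293 cells for agonist activity at Glucose-dependent insulinotropic receptor (Homo sapiens), read by reporter gene assay and cAMP accumulation, with a stated time of 6 h (on this read-out higher numbers stand for an effect only at larger amounts of compound and lower numbers for an effect already at smaller amounts), compound 1 gives 8.3 nM, the lowest number of the three; compound 2 and compound 3 stand above it by a 2.5-fold higher number from compound 1 to compound 2 (0.40 log units; beyond the scatter) and a 2.2-fold higher number from compound 1 to compound 3 (0.34 log units; beyond the scatter). Compound 4 `CNC(=O)C1CCN(c2nc(-c3cc(F)c(Cl)cc3F)nc3c2CS(=O)(=O)C3)CC1` has not been measured. It differs from compound 1 as follows: methylcarbamoyl in place of carbamoylmethyl on a saturated ring carbon. The closest measured step is a 2.5-fold higher number from compound 1 to compound 2 (0.40 log units; beyond the scatter), where the amide moves onto the ring carbon; compound 4 keeps that placement but carries a methyl on the amide nitrogen, for which there is no measured comparison. Compound 4 is therefore expected to land near compound 2, with a 3.0-fold higher number from compound 1 to compound 4 (0.48 log units; beyond the scatter). The estimate for compound 4 in this assay is 25 nM, ranging from 9 nM to 70 nM.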

Compound 4, effective concentration (reported as EC, without a stated level of effect): 51 nM
Beside the measured number, compound 4's estimate is 2.0-fold (0.31 log units) below it; the range from low to high includes it.
By their numbers in this assay, from the lowest: compound 1; then compounds 3 and 2 (each within the scatter of the next); then compound 4.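

Placing a methyl on the amide nitrogen, with the amide kept on the saturated ring carbon, is not neutral: in this assay it gives a 2.4-fold higher number from compound 2 to compound 4 (0.39 log units; beyond the scatter). The same atoms joined differently give a 6.1-fold higher number from compound 1 to compound 4 (0.79 log units; beyond the scatter), the largest step in the set, and the methylcarbamoyl group also stands apart from the 2-carbamoylethyl chain, with a 2.8-fold higher number from compound 3 to compound 4 (0.45 log units; beyond the scatter). Nothing shown gives a reason for these steps.

Going by these compounds, whether a methyl on the amide nitrogen acts the same way on the carbamoylmethyl chain remains open. So does the outcome with an ethyl on that nitrogen, or a carboxylic acid replacing the amide.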